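Replacing the nitro group of compound 2

The compounds below may be only part of what the source reports. "The series", "measured", "known", "first", "only" and "open" are said of these compounds alone.

Measured in a functional assay on DU-145 cells (Homo sapiens) for cytotoxicity, read by trypan blue exclusion, with a stated time of 96 h; a lower number here means a stronger inhibitor, a higher number a weaker inhibitor:
- compound 1 `COc1ccc(CS(=O)(=O)/C=C/c2c(OC)cccc2OC)cc1[N+](=O)[O-]`: 20000 nM
- compound 2 `COc1cc(OC)c(/C=C/S(=O)(=O)Cc2ccc(OC)c([N+](=O)[O-])c2)c(OC)c1`: 2500 nM
- compound 3 `COc1cc(OC)c(/C=C/S(=O)(=O)Cc2ccc(Br)c([N+](=O)[O-])c2)c(OC)c1`: 25000 nM

Among these three, compound 2 has the lowest number, at 2500 nM. The next compound to be tested is compound 4 `COC(=O)CNc1cc(CS(=O)(=O)/C=C/c2c(OC)cc(OC)cc2OC)ccc1OC`. It carries ((methoxycarbonyl)methyl)amino in place of nitro on an aromatic carbon, ortho to a methoxy group: ((methoxycarbonyl)methyl)amino in place of nitro on an aromatic carbon.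

Two measured steps offer a guide, though only an indirect one. With methoxy in place of hydrogen on an aromatic carbon, the record shows an 8.0-fold lower number from compound 1 to compound 2 (0.90 log units; beyond the scatter). With bromo in place of methoxy on an aromatic carbon, it shows a 10-fold higher number from compound 2 to compound 3 (1.00 log units; beyond the scatter). Both are modest, yet neither touches the nitro group, which all three measured compounds keep. The data therefore give no direct reading of this replacement and do not fix its direction.

A change of similar size is expected in this assay, with only a tentative lean towards a lower number. The estimated change is a 6.3-fold lower number from compound 2 to compound 4 (0.80 log units; beyond the scatter). For compound 4 the expected value is 400 nM, with an estimated range from 40 nM to 4000 nM.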

Compound 4, half-maximal inhibitory concentration: 100 nM
Beside the measured number, compound 4's estimate is 4.0-fold (0.60 log units) above it; the range from low to high includes it.
By their numbers in this assay, from the lowest: compound 4; then compound 2; then compounds 1 and 3 (each within the scatter of the next).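

In this assay, the nitro group kept by compounds 1, 2 and 3 proves replaceable at this position, ortho to a methoxy group: ((methoxycarbonyl)methyl)amino gives a 25-fold lower number from compound 2 to compound 4 (1.40 log units; beyond the scatter). The earlier steps shown here were modest and concerned other places on the molecule, whereas this large step shows that the number at this position can fall substantially when nitro leaves and a group with more heavy atoms and a hydrogen-bond donor enters. Nothing available here bears on why the number falls with this change.

The compounds shown leave open which part of the new group accounts for the step, as the amino nitrogen, the methylene and the methyl ester all enter together. A plain amine at this position, a carboxylic acid in place of the methyl ester, or a longer chain carrying the ester would each test a different part of that group, and the compounds shown do not say how any of them would read in this assay.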